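The source may report more compounds than this note shows. Statements on the series, on what has been measured and on what is new or still open speak of the compounds shown alone.

In a physicochemical assay for solubility, in phosphate buffer, measured as kinetic solubility, with a stated time of 24 h, at pH 7.4 (a lower number here means a less soluble compound, a higher number a more soluble compound), compound 1 (`CC(C)CN(Cc1ccc(N2CCN(NS(C)(=O)=O)CC2)cc1)S(=O)(=O)Cc1ccccc1`) gives <= 1000 nM, which is a limit. Compound 2 (`CC(C)CN(Cc1ccc(N2CCC(C(N)=O)CC2)cc1)S(=O)(=O)Cc1ccccc1`) gives <= 1000 nM, again a limit, and its standing is known no more closely than that. Among the compounds with values here, the series so far sits at the limit of <= 1000 nM in this assay, at which 2 of the 2 values shown sit. Within the data shown here, the only measured step is a step that the two limits leave unreadable from compound 1 to compound 2, and it offers no size to carry forward. Compound 3 (`CC(=O)N1CCN(c2ccc(CN(CC(C)C)S(=O)(=O)Cc3ccccc3)cc2)CC1`) has 4-acetylpiperazin-1-yl in place of 4-carbamoylpiperidin-1-yl on an aromatic carbon. No shift beyond the scatter, in either direction, is expected. The expected step is a step that the limit leaves unreadable from compound 2 to compound 3. The estimate for compound 3 is 800 nM, with an expected range of 300 nM to 2000 nM.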

Compound 3, solubility: <= 1000 nM
Compound 3 was reported as a limit; the forecaster's own chance of this, stated with the estimate: 80%; the middle value does not contradict the limit.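

Within the data shown here, no step among compound 1, compound 2 and compound 3 can be read in this assay, since all three are reported only as limits: the limit of <= 1000 nM in this assay, at which 3 of the 3 values shown sit. From the compounds shown here alone, whether these three compounds differ at all in solubility, and in which order, stays open.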